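A few compounds are considered here, and "the series" means these few. Any claim that something is new, unique, unknown or untested is made for them only; others in the source may bear on it.

Measured compounds:
- compound 1 `CC(C)(C)OC(=O)N1CCCN(CCCCCOc2c(Br)cc(Br)cc2Oc2ccc(Br)cc2Br)CC1` — 44.8 ug/mL
- compound 2 `C=CCOc1c(Br)cc(Br)cc1Oc1ccc(Br)cc1Br` — 27.9 ug/mL
- compound 3 `Brc1ccc(Oc2cc(Br)cc(Br)c2OCCCCCN2CCN(C/C=C/c3ccccc3)CC2)c(Br)c1` — 47.2 ug/mL

All three were tested in a functional assay on HL-60 cells (Homo sapiens) for cytotoxicity, read by MTT assay, with a stated time of 24 h; on this read-out higher numbers stand for weaker inhibition and lower numbers for stronger inhibition. Compound 1 gives 44.8 ug/mL, compound 2 gives 27.9 ug/mL and compound 3 gives 47.2 ug/mL. On these numbers compound 2 holds the smallest value of the three, but its gap to compound 1 and its gap to compound 3 each lie within the usual scatter of this assay, so no ranking of the three can be drawn from them. The two larger compounds carry a long chain ending in a saturated ring system on the oxygen of the shared core, while compound 2 carries only an allyloxy group there; the numbers do not separate these cases.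

The next compound to be measured is compound 4 `COc1c(Br)cc(Br)cc1Oc1ccc(Br)cc1Br`. It differs from compound 2 in one place: hydrogen in place of vinyl on a saturated chain carbon bound to an oxygen on an aromatic ring. Within the data shown here, no pair of measured compounds that differ in a single place is available, so the size of this step cannot be read from the data. Given that compounds with very different groups on the same oxygen all fall within the scatter of each other, the author expects a 1.1-fold higher number from compound 2 to compound 4 (0.03 log units; within the scatter), that is, no movement beyond the scatter in either direction. Compound 4 is therefore estimated at 30 ug/mL, with a range from 15 ug/mL to 60 ug/mL.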

Compound 4, half-maximal inhibitory concentration: 28.2 ug/mL
Compound 4: middle estimate off by 1.1-fold (0.03 log units), on the high side, within the range that was stated.
By their numbers in this assay, from the lowest: compounds 2, 4, 1 and 3 (each within the scatter of the next).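

In this assay, taking away the vinyl on a saturated chain carbon bound to an oxygen on an aromatic ring, with hydrogen entering in its place, gives a 1.0-fold higher number from compound 2 to compound 4 (0.00 log units; within the scatter). Among these compounds, this is the first direct reading at this position, since the earlier compounds included no pair differing in one place, and it shows that cutting allyloxy back to methoxy, with the loss of the double bond outside the aromatic rings, leaves the number within the scatter. No supporting measurement is available to explain this result, so the step stands as an observation alone.

The step covers only allyloxy and methoxy on this oxygen of the shared core, so it cannot say how a free hydroxyl in place of these groups, or a short chain ending in a carboxylic acid, would read in this assay. Among the compounds shown here, whether the vinyl can be lost just as freely when other groups on the core are changed also remains open, as this single pair is the only evidence on that change.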